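The source may hold more compounds than are shown below. What is called first, only, known or untested is meant among the compounds shown, and "the series" means these compounds.

In an ADME assay on PBMC cells (Homo sapiens) for cytotoxicity (on this read-out higher numbers stand for lower toxicity in this test and lower numbers for higher toxicity in this test), compound 3 `Cc1cccnc1OC(c1ccc(C(F)(F)F)cc1)C1CCN(C(C)CCNC(=O)c2c(Cl)cncc2Cl)CC1` gives 33000 nM. Compound 1 `COc1cccc(OC(c2ccc(C(F)(F)F)cc2)C2CCN(C(C)CCNC(=O)c3c(Cl)cncc3Cl)CC2)n1` gives 32700 nM, so the two stand level, with a 1.0-fold higher number from compound 1 to compound 3 (0.00 log units; within the scatter). Compound 2 `CC(CCNC(=O)c1c(Cl)cncc1Cl)N1CCC(C(Oc2cccc(Cl)n2)c2ccc(C(F)(F)F)cc2)CC1` reads > 32500 nM, which is a limit of the assay and not a number.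

Compound 4 `CC(CCNC(=O)c1c(Cl)cncc1Cl)N1CCC(C(Oc2cc(Cl)ccn2)c2ccc(C(F)(F)F)cc2)CC1` keeps the shared core and differs from compound 3 in one group: 4-chloropyridin-2-yl in place of 3-methylpyridin-2-yl on an oxygen on a saturated carbon. Here, 4-chloropyridin-2-yl takes the place of 3-methylpyridin-2-yl on an oxygen on a saturated carbon.

Three measured steps change the group at this same place. The only one with a readable size is a 1.0-fold higher number from compound 1 to compound 3 (0.00 log units; within the scatter). The two that involve a chloro-bearing ring, a step that the limit leaves unreadable from compound 1 to compound 2 and a step that the limit leaves unreadable from compound 2 to compound 3, give no size. Among the measured compounds shown here, nothing measured so far therefore points to a real shift, although only three compounds support this view.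

The expected change is none beyond the scatter, with an estimate of a 1.1-fold lower number from compound 3 to compound 4 (0.04 log units; within the scatter). Compound 4 is expected at about 30000 nM, with an estimated range of 15000 nM to 38000 nM.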

Compound 4, half-maximal cytotoxic concentration: 4260 nM
Estimate against measurement, compound 4: 7.0-fold (0.85 log units) above, outside the stated range (below it).
By their numbers in this assay, from the lowest: compound 4; then compounds 1 and 3 (each within the scatter of the next).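

In this assay, the group on this oxygen turns out to matter, which the level values of compounds 1 and 3 did not reveal: the change to 4-chloropyridin-2-yl gives a 7.7-fold lower number from compound 3 to compound 4 (0.89 log units; beyond the scatter) and a 7.7-fold lower number from compound 1 to compound 4 (0.89 log units; beyond the scatter), so compound 4 is the more toxic in this test. Chloro alone does not account for this, since compound 2 also carries a chloro-bearing ring, and the change from 6-chloropyridin-2-yl to 4-chloropyridin-2-yl gives an at least 7.6-fold lower number from compound 2 to compound 4 (0.88 log units; beyond the scatter). Compound 2 has a limit of the assay and not a number: the limit of > 32500 nM in this assay, at which 1 of the 4 values shown sits.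

As far as these compounds go, it remains open whether 4-methylpyridin-2-yl or 4-methoxypyridin-2-yl would give a similar drop, which would show whether the effect belongs to the chloro itself or to any group at that ring place. From the compounds shown here alone, what causes the drop in compound 4 also remains unknown.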